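Replacing Trifluoromethyl with Cyano: What to Expect

The compounds below may be only part of what the source reports. "The series", "measured", "known", "first", "only" and "open" are said of these compounds alone.

Compound 1, `CC(C)c1ccc(-n2nc(-c3ccc(C(F)(F)F)cc3O)nc2-c2ccccc2O)cc1`: 108%
Compound 2, `Oc1cc(C(F)(F)F)ccc1-c1nc(-c2ccccc2O)n(-c2ccc(Br)cc2)n1`: 100%
Compound 3, `Oc1cc(C(F)(F)F)ccc1-c1nc(-c2ccccc2O)n(-c2ccc(C(F)(F)F)cc2)n1`: 102%

These three compounds were tested in a functional assay on PC-12 cells (Rattus norvegicus) for cytotoxicity, read by MTT assay, with stated times of 2 h and 24 h, tested at 10 uM; a higher number here means a stronger effect of the compound at the concentration tested, a lower number a weaker effect. Compound 3 stands second highest of the three numbers, with compound 2 nearest and compound 1 furthest, and both gaps lie within the scatter, so the three cannot be told apart on these readings.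

Compound 4, `N#Cc1ccc(-n2nc(-c3ccc(C(F)(F)F)cc3O)nc2-c2ccccc2O)cc1`, has not yet been measured. It differs from compound 3 in one place: cyano in place of trifluoromethyl on an aromatic carbon. Three measured steps change a group at this same place on the same ring: a number 8 percentage points lower from compound 1 to compound 2 (within the scatter), a number 6 percentage points lower from compound 1 to compound 3 (within the scatter) and a number 2 percentage points higher from compound 2 to compound 3 (within the scatter). Every one of them stayed within the scatter. Within the data shown here, each swap at this place so far left this assay essentially unchanged, and no step beyond the scatter is expected from the present swap either.

Compound 4 is therefore expected to give about 100%, with a range from 88% to 112%. This estimate corresponds to an expected step of a number 2 percentage points lower from compound 3 to compound 4 (within the scatter).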

Compound 4, a percentage reported as activity, at one concentration (the size of the read-out at that concentration, not a potency): 98.9%
Beside the measured number, compound 4's estimate is 1.1 percentage points above it; the measured number falls inside the stated range.
By their numbers in this assay, from the lowest: compounds 4, 2, 3 and 1 (each within the scatter of the next).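

In this assay, cyano brings a triple bond and a hydrogen-bond acceptor that trifluoromethyl lacks, yet the reading stays within the scatter against all three earlier compounds: a number 3.1 percentage points lower from compound 3 to compound 4 (within the scatter), a number 1.1 percentage points lower from compound 2 to compound 4 (within the scatter), and a number 9.1 percentage points lower from compound 1 to compound 4 (within the scatter). Isopropyl, bromo, trifluoromethyl and cyano, placed at this same spot on the ring, therefore give readings in this assay that cannot be told apart, and this now holds for a group containing nitrogen as well. No other measurement is available here that would explain this lack of change.

From the compounds shown here alone, it remains open whether a group of another kind at this place, such as an amine or a carboxylic acid, would move the reading. Because all four readings come from a single concentration, they also leave open how the compounds would compare at other concentrations.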